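The source may report more compounds than this note shows. Statements on the series, on what has been measured and on what is new or still open speak of the compounds shown alone.

Compound 1 `CC(C)CCn1c(Cn2c(=O)n(C(C)C)c3ccccc32)nc2cc(CNC3CC3)ccc21` and compound 2 `CC(C)CCn1c(Cn2c(=O)n(C(C)C)c3ccccc32)nc2c(CCC#N)cccc21` share a common core and have each been tested in an ADME assay on HEp-2 cells (Homo sapiens) for cytotoxicity; a lower number here means that less compound is tolerated, a higher number that more compound is tolerated. Compound 1 gives 17200 nM, the highest of the two numbers recorded, while compound 2 gives 2240 nM, a value that sits well beyond the scatter below it. These two compounds differ in more than one place, so their gap cannot be tied to any single change.

Compound 3 `COC(=O)c1ccc2c(c1)nc(Cn1c(=O)n(C(C)C)c3ccccc31)n2CCC(C)C` is not yet measured. It differs from compound 1 in one place: methoxycarbonyl in place of (cyclopropylamino)methyl on an aromatic carbon. For the measured compounds named here, no measured pair shows this exact change, so no step between measured compounds is available to guide the expectation. On that basis, the step of a 1.4-fold lower number from compound 1 to compound 3 (0.16 log units; within the scatter) is expected to be modest, pointing toward a somewhat lower number but not clearly beyond the scatter. Compound 3 is therefore estimated at 12000 nM, with a plausible range from 4000 nM to 35000 nM.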

Compound 3, half-maximal cytotoxic concentration: 33700 nM
The estimate for compound 3 lay 2.8-fold (0.45 log units) below the measured number; the range from low to high includes it.
By their numbers in this assay, from the lowest: compound 2; then compounds 1 and 3 (each within the scatter of the next).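

Compound 1 and compound 3 differ only in the group on one aromatic carbon, and placing methoxycarbonyl there in place of (cyclopropylamino)methyl gives a 2.0-fold higher number from compound 1 to compound 3 (0.29 log units; within the scatter) in this assay. The two groups differ clearly: the one that leaves has a three-membered ring and a hydrogen-bond donor, the one that enters has neither, yet the two compounds cannot be told apart in this assay. Nothing at hand explains why these groups give such similar numbers.

Going by these compounds, whether the same holds for other groups on this aromatic carbon remains open, such as a carboxylic acid or a longer amine chain. On these data alone, it is also open whether methoxycarbonyl would give a similar number on a different carbon of the same aromatic ring.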